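The source may report more compounds than this note shows. Statements on the series, on what has been measured and on what is new or still open speak of the compounds shown alone.

Measured so far:
- Compound 1 `O=S(=O)(c1ccc(F)c(Cl)c1)c1cnc2cc(F)ccc2c1-c1cccc(Cl)c1`, in an ADME assay on microsomes from liver (Homo sapiens) for metabolic stability, tested at 2.5 uM (a lower number here means slower removal, a higher number faster removal of the compound), compound 1 gives 0.66 mL/min.
- Compound 2 `COc1ccc(S(=O)(=O)c2cnc3cc(F)ccc3c2-c2ccc(F)cc2)cc1`, in this assay compound 2 gives 1.71 mL/min.

Compound 2 stands at the higher of the two numbers in this assay; compound 1 lies lower by a margin that is beyond the usual scatter. For the measured compounds named here, the two compounds differ in two places at once, so no single step between them can be read off.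

Compound 3 `O=S(=O)(c1ccc(F)c(Cl)c1)c1cnc2cc(F)ccc2c1-c1ccc(F)cc1` is not yet measured. It is reached from compound 2 by one change on the sulfonyl sulfur: 3-chloro-4-fluorophenyl in place of 4-methoxyphenyl on a sulfonyl sulfur. The 3-chloro-4-fluorophenyl that enters is the same group that compound 1 carries on its sulfonyl sulfur, while the 4-fluorophenyl of compound 2 is kept.

A step downward in this assay is expected from compound 2 to compound 3, of about a 1.9-fold lower number from compound 2 to compound 3 (0.28 log units; within the scatter), because compound 1, which shares the entering group, gives 0.66 mL/min; the two compounds still differ in the other aryl, so the expectation is held loosely. Compound 3 is estimated at 0.9 mL/min, within 0.45 mL/min to 1.8 mL/min.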

Compound 3, intrinsic clearance in a liver preparation (reported as CLH), per the amount of preparation that the assay uses: 0.69 mL/min
Estimate against measurement, compound 3: 1.3-fold (0.12 log units) above; measured number inside the range.
By their numbers in this assay, from the lowest: compounds 1 and 3 (each within the scatter of the next); then compound 2.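

In this assay, the group on the sulfonyl sulfur now has a step of its own: 3-chloro-4-fluorophenyl in place of 4-methoxyphenyl, with the 4-fluorophenyl kept, gives a 2.5-fold lower number from compound 2 to compound 3 (0.39 log units; beyond the scatter). The aryl on the aromatic carbon can also be read alone: 4-fluorophenyl in place of 3-chlorophenyl, with the 3-chloro-4-fluorophenyl kept, gives a 1.0-fold higher number from compound 1 to compound 3 (0.02 log units; within the scatter), so of the two single changes shown, only the one on the sulfonyl sulfur goes beyond the scatter. No measurement on these compounds bears on what lies behind the step at the sulfonyl sulfur.

As far as these compounds go, each step is read once, on a single background, and the chlorine and fluorine of the entering group arrive together, so their separate shares and whether the step holds with 3-chlorophenyl on the aromatic carbon stay open. Also open, from the compounds shown here alone, is how the number responds when the group on the sulfonyl sulfur carries an amine or a carboxylic acid, or when a saturated ring such as cyclohexyl stands there in place of an aromatic ring.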